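The compounds below may be only part of what the source reports. "The series", "measured", "known", "first", "only" and "open" are said of these compounds alone.

Measured so far in an ADME assay on BAEC cells (Bos taurus) for cytotoxicity, read by MTT assay, with a stated time of 2 days; on this read-out higher numbers stand for weaker inhibition and lower numbers for stronger inhibition:
Compound 1 `COc1c(Br)cc(/C=C2\N=C(c3ccccc3)OC2=O)c(OC(=O)c2ccccc2)c1Br`: > 18000 nM
Compound 2 `COc1c(Br)cc(/C=C2\N=C(c3ccccc3)OC2=O)c(O)c1Br`: > 22000 nM

Compound 2 stands at > 22000 nM, which is a limit and not a number. Compound 3 `COc1c(Br)cc(/C=C2\N=C(c3ccccc3)OC2=O)c(OC(=O)c2ccc(N(C)C)cc2)c1Br` differs from compound 2 by (4-(dimethylamino)phenyl)carbonyl in place of hydrogen on an oxygen on an aromatic ring. For the measured compounds named here, the one measured step that bears on this is a step that the two limits leave unreadable from compound 1 to compound 2, which concerns a benzoyl group on that same kind of oxygen and runs in the reverse sense. Compound 1, the benzoyl compound, gives > 18000 nM, also a limit. No size or direction can be taken from that step, so no change beyond the scatter is expected in this assay, and a further limit is the likeliest report. The estimated step is a number no higher from compound 2 to compound 3 (the limit leaves the size open). For compound 3 the expected value is 22000 nM, with an estimated range of 9000 nM to 50000 nM.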

Compound 3, half-maximal inhibitory concentration: 83000 nM
For compound 3 the middle estimate is 3.8-fold (0.58 log units) below the measured one, outside the stated range (above it).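

Compound 1 and compound 2 are reported only as limits, so neither step to compound 3 can be read in this assay. The compounds shown leave open whether the dimethylamino or (4-(dimethylamino)phenyl)carbonyl change shifts this read-out at all, and by how much.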